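The source may report more compounds than this note shows. Statements on the series, on what has been measured and on what is new or still open speak of the compounds shown alone.

For the measured compounds named here, only two compounds have been tested so far in a functional assay on K562 cells (Homo sapiens), read by MTT assay, with a stated time of 72 h (a lower number here means a stronger inhibitor, a higher number a weaker inhibitor), and neither is a strong inhibitor. Going by the values given here, compound 2 `CN(C)c1ncnc2c1c(-c1ccoc1)cn2[C@@H]1O[C@H](CO)[C@@H](O)[C@H]1O` gives 14900 nM, the only actual number available. Compound 1 `CNc1ncnc2c1c(-c1cc3ccccc3o1)cn2[C@@H]1O[C@H](CO)[C@@H](O)[C@H]1O` is reported only as a limit, > 20000 nM.

The next step leads to compound 3 `CN(C)c1ncnc2c1c(-c1cc3ccccc3o1)cn2[C@@H]1O[C@H](CO)[C@@H](O)[C@H]1O`, which keeps everything in compound 2 except one group. It has 1-benzofuran-2-yl in place of furan-3-yl on an aromatic carbon of a five-membered aromatic ring with 1 nitrogen (1-benzofuran-2-yl in place of furan-3-yl on an aromatic carbon). The incoming group thus brings one six-membered aromatic ring of carbon only along with its five-membered aromatic ring.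

Among the compounds with values here, no measured pair shows this change on its own, so the data give no direct guide to the size of the step. The expectation therefore starts from compound 2 at 14900 nM, and no shift beyond the usual scatter of this assay is expected, with any drift more likely towards weaker inhibition. The estimated step of a 1.1-fold higher number from compound 2 to compound 3 (0.03 log units; within the scatter) is correspondingly small, and a result reported only as a limit would be no surprise. Compound 3 is expected at 16000 nM, with an estimated range from 5000 nM to 40000 nM.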

Compound 3, half-maximal inhibitory concentration: > 20000 nM
Compound 3: only a limit was reported (the forecaster's own chance of this, stated with the estimate: 55%); middle value at least 1.2-fold (0.09 log units) away from the limit.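

For the compounds shown here, compound 2 and compound 3 form the first measured pair that isolates a change at this position, on an aromatic carbon of a five-membered aromatic ring with 1 nitrogen. In this assay, 1-benzofuran-2-yl in place of furan-3-yl gives an at least 1.3-fold higher number from compound 2 to compound 3 (0.12 log units; that floor lies within the scatter), so the added six-membered aromatic ring of carbon only brings no visible gain in inhibition. Compound 3 is reported only as a limit and not as a number, which makes that step a floor whose true size is unknown, and the data now reach the end of what this assay reports for most of these compounds: the limit of > 20000 nM in this assay, at which 2 of the 3 values shown sit.

The step between compound 1 and compound 3, methyl in place of hydrogen on a nitrogen on an aromatic ring, cannot be read, as both values are limits. Still open, from the compounds shown here alone, is whether a different group at this position, such as an amine, a carboxamide or a short alkyl chain, would give a clearly lower number than the furan-3-yl of compound 2.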